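Notes on the amide aryl group in the shared core series

A few compounds are considered here, and "the series" means these few. Any claim that something is new, unique, unknown or untested is made for them only; others in the source may bear on it.

Compound 2 `Cc1ccc(C(=O)Nc2cccc(-c3oc4cc(-c5ccc(F)cc5)ccc4c(=O)c3O)c2)cc1` is one of three measured analogues built on the shared core. In a functional assay on GTL 16 cells for antiproliferative activity against GTL 16 cell line (Homo sapiens), read by CCK-8 assay, with a stated time of 72 h (on this read-out lower numbers stand for stronger inhibition and higher numbers for weaker inhibition), compound 2 gives 12900 nM, the second highest of the three numbers. Compound 1 `O=C(Nc1cccc(-c2oc3cc(-c4ccc(F)cc4)ccc3c(=O)c2O)c1)c1ccc(F)cc1` gives 14600 nM in this assay, and compound 3 `COc1ccccc1C(=O)Nc1cccc(-c2oc3cc(-c4ccc(F)cc4)ccc3c(=O)c2O)c1` gives 6370 nM. The step of a 1.1-fold lower number from compound 1 to compound 2 (0.05 log units; within the scatter) lies within the scatter, while a 2.3-fold lower number from compound 1 to compound 3 (0.36 log units; beyond the scatter) and a 2.0-fold lower number from compound 2 to compound 3 (0.31 log units; beyond the scatter) are modest shifts beyond it.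

Compound 4 `O=C(Nc1cccc(-c2oc3cc(-c4ccc(F)cc4)ccc3c(=O)c2O)c1)c1ccc(C(F)(F)F)cc1` has not yet been measured. Its difference from compound 2 is trifluoromethyl in place of methyl on an aromatic carbon. The measured step that bears most directly on it is the exchange on the same aromatic carbon, a 1.1-fold lower number from compound 1 to compound 2 (0.05 log units; within the scatter), which stayed within the scatter; the other two measured steps replace the whole aryl group on the carbonyl carbon and are only modest in size. Among the measured compounds shown here, no measured step reaches a trifluoromethyl group, so the expectation rests on the small effect seen when fluoro became methyl at this place. The expected step is a 1.1-fold lower number from compound 2 to compound 4 (0.03 log units; within the scatter), which need not exceed the scatter. The estimate for compound 4 in this assay is 12000 nM, with a range from 5000 nM to 30000 nM.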

Compound 4, half-maximal inhibitory concentration: 33000 nM
For compound 4 the middle estimate is 2.8-fold (0.44 log units) below the measured one; measured number above the stated range.
By their numbers in this assay, from the lowest: compound 3; then compounds 2 and 1 (each within the scatter of the next); then compound 4.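

Trifluoromethyl at this place, para to a large group, separates from both smaller groups in this assay: the steps are a 2.6-fold higher number from compound 2 to compound 4 (0.41 log units; beyond the scatter) and a 2.3-fold higher number from compound 1 to compound 4 (0.35 log units; beyond the scatter), whereas the exchange of fluoro for methyl at the same carbon had stayed within the scatter, so this position is not indifferent to its substituent. The widest step in the series is now a 5.2-fold higher number from compound 3 to compound 4 (0.71 log units; beyond the scatter), and compound 4 has the highest number of the four, with its steps to every other compound beyond the scatter. No supporting measurement accounts for the loss seen with trifluoromethyl at this carbon.

Compound 3 differs from the other compounds in both the group and its place on the ring, so the methoxy group's contribution cannot be separated from that of its location, and a 4-methoxyphenyl or 2-(trifluoromethyl)phenyl amide would be needed to divide the two. On these data alone, how far the para carbon tolerates other kinds of group also remains open, for example a nitrile, a carboxylic acid, an amine or a longer alkyl chain such as propyl.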